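This account rests on a few compounds, and the source may have more. Where it says the series, first, only, none or still open, it means among the compounds named here.

Measured so far in a physicochemical assay for lipophilicity, using the shake flask method, measured as octanol-water partition, at pH 7.4 (on this read-out higher numbers stand for higher lipophilicity and lower numbers for lower lipophilicity), are these three compounds
- compound 1 (`CC(=O)N[C@@H]1CCC[C@H](C(=O)Nc2cc(-c3cnc(C)n3C(C)C)ccn2)C1`) gives 1.9
- compound 2 (`CC(=O)N[C@@H]1CCC[C@H](C(=O)Nc2cc(-c3cnn4c3CCCC4)c(Cl)cn2)C1`) gives 3.2
- compound 3 (`CC(=O)N[C@@H]1CCC[C@H](C(=O)Nc2cc(-c3cnc4n3CCCC4)c(Cl)cn2)C1`) gives 2.7

Compound 3 (2.7) stands in the middle, beyond the scatter from both others, lower than compound 2 and higher than compound 1. Compound 4 (`CC(=O)N[C@@H]1CCC[C@H](C(=O)Nc2cc(-c3cnn4c3CCC4)c(Cl)cn2)C1`) is not yet measured. Compared with compound 3, it carries a group of 8 heavy atoms (6 carbon, 2 nitrogen; one five-membered non-aromatic ring with 1 hetero atom, one five-membered aromatic ring with 2 hetero atoms) in place of a group of 9 heavy atoms (7 carbon, 2 nitrogen; one five-membered aromatic ring with 2 hetero atoms, one six-membered non-aromatic ring with 1 hetero atom), on an aromatic carbon (opposite the ring nitrogen, ortho to a chloro group). Among the measured compounds shown here, one measured step bears on this, between two groups of equal size (a number 0.50 log units lower from compound 2 to compound 3 (beyond the scatter)). The smaller group of compound 4 places its ring nitrogens as in compound 2 (3.2), so only a little movement is expected in this assay overall. The expected step is a number 0.10 log units higher from compound 3 to compound 4 (within the scatter) here. Compound 4 is estimated at 2.8, with an expected range from 2.4 to 3.2.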

Compound 4, distribution coefficient: 2.9
Estimate against measurement, compound 4: 0.10 log units below, and the stated range covers the measured number.
By their numbers in this assay, from the lowest: compound 1; then compounds 3, 4 and 2 (each within the scatter of the next, the first and the last beyond it).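

On the aromatic carbon opposite the ring nitrogen, this assay shows a number 0.20 log units higher from compound 3 to compound 4 (within the scatter) and also a number 0.30 log units lower from compound 2 to compound 4 (within the scatter). The group with the five-membered non-aromatic ring therefore cannot be separated from either of the two larger groups, even though those two stand apart, with a number 0.50 log units lower from compound 2 to compound 3 (beyond the scatter) beyond the scatter. No measurement shown here offers an explanation for this. Still open, from the compounds shown here alone, is how this read-out would respond to a seven-membered non-aromatic ring at this position, or to an amine on the non-aromatic ring.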